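The source may hold more compounds than are shown below. What is called first, only, known or untested is meant among the compounds shown, and "the series" means these compounds.

Working notes on the series in an assay on HEK293 cells for inhibition of nuclear factor NF-kappa-B complex (Homo sapiens), read by a luciferase reporter, with stated times of 1 h and 3 h; a higher number here means a weaker inhibitor, a lower number a stronger inhibitor. Of the compounds shown here, three have numbers so far. Compound 1 `Cc1ccc(CNC(=O)[C@H](CCc2ccccc2)NC(=O)[C@H](CCc2ccccc2)NC(=O)[C@H](CCc2ccccc2)NC(=O)c2cnc(C)cn2)cc1` gives 45 nM. Compound 2 `CC(C)(C)CNC(=O)C[C@H](NC(=O)C(C)(C)C)C(=O)N[C@@H](CCc1ccccc1)C(=O)NCc1ccccc1` gives 62 nM. Compound 3 `CC(C)(C)CNC(=O)C[C@H](NC(=O)CN1CCCCC1)C(=O)N[C@@H](CCc1ccccc1)C(=O)NCc1ccccc1` gives 62 nM, level with compound 2 at the digits printed; together the two hold the highest numbers of the three, while compound 1 lies within the scatter of both, so no order among the three can be read from these values. For the measured compounds named here, the one single-point change measured so far, no change at the digits printed from compound 2 to compound 3 (within the scatter), replaced the group on the carbonyl carbon of the terminal amide and left the number where it was.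

Compound 4 `CC(C)(C)CNC(=O)C[C@H](NC(=O)CCc1ccccc1)C(=O)N[C@@H](CCc1ccccc1)C(=O)NCc1ccccc1` is the next member. Relative to compound 3 the change is benzyl in place of piperidin-1-yl on a saturated chain carbon bound to a carbonyl carbon. Going by the values given here, the only measured step that bears on it is the preceding exchange at the same carbonyl, no change at the digits printed from compound 2 to compound 3 (within the scatter), which was flat; it already showed that an exchange of a tert-butyl for a (piperidin-1-yl)methyl there does not move this assay. On that basis the further exchange to phenethyl is expected to give no step beyond the scatter, no change at the digits printed from compound 3 to compound 4 (within the scatter). Compound 4 is therefore estimated at 62 nM, within a range of 30 nM to 130 nM, pending measurement.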

Compound 4, half-maximal inhibitory concentration: 12 nM
Compound 4: the middle estimate sits 5.2-fold (0.71 log units) above what was measured; the measured number lies below the stated range.
By their numbers in this assay, from the lowest: compound 4; then compounds 1, 2 and 3 (each within the scatter of the next).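

In this assay this position proves able to move the number: benzyl in place of piperidin-1-yl on a saturated chain carbon bound to a carbonyl carbon gives a 5.2-fold lower number from compound 3 to compound 4 (0.71 log units; beyond the scatter) and sets compound 4 apart from both earlier members of the pair, since phenethyl in place of tert-butyl on a carbonyl carbon gives a 5.2-fold lower number from compound 2 to compound 4 (0.71 log units; beyond the scatter) as well. The flat exchange, no change at the digits printed from compound 2 to compound 3 (within the scatter) between the same two neighbours, therefore showed only that tert-butyl and (piperidin-1-yl)methyl sit level here, and did not show that the position is indifferent to every group. No measurement in hand bears on why phenethyl lowers the number at this position.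

The compounds shown do not separate the contribution of the six-membered aromatic ring of carbon only from that of the chain carrying it, a question that a saturated 2-cyclohexylethyl group would address directly. They also leave open how the number responds to a shorter benzyl or longer 3-phenylpropyl group on the same carbonyl carbon, or to a pyridine ring or a fluorine atom on the phenethyl group.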